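A few compounds are considered here, and "the series" means these few. Any claim that something is new, unique, unknown or untested is made for them only; others in the source may bear on it.

Values in a functional assay on LOX IMVI cells (Homo sapiens) for cytotoxicity, read by sulforhodamine B assay, with a stated time of 48 h, tested at 100 nM (a higher number here means a weaker effect of the compound at the concentration tested, a lower number a stronger effect), so far:
compound 1, `COc1cc(C)cc(-c2nn(CC#N)cc2-c2ccc(-c3cccc(C(C)=O)c3)nc2)c1`, gives 82%.
compound 2, `Cc1cc(O)cc(-c2nn(CC#N)cc2-c2ccnc(-c3ccc(Oc4ccccc4)cc3)c2)c1`, gives 103%.
compound 3, `COc1cc(C)cc(-c2nn(CC#N)cc2-c2ccnc(-c3ccc(N(C)C)cc3)c2)c1`, gives 39%.

Compound 3 stands lowest of the three, the strongest effect seen. Compound 1 is nearest, with a number higher by a gap beyond the scatter; compound 2 lies furthest, higher still by a gap beyond the scatter. Compound 2 differs from compound 3 in more than one place, so its value alone does not separate the two differences.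

Compound 4, `Cc1cc(O)cc(-c2nn(CC#N)cc2-c2ccnc(-c3ccc(N(C)C)cc3)c2)c1`, differs from compound 3 by hydrogen in place of methyl on an oxygen on an aromatic ring. Among the compounds with values here, no measured pair isolates this change. Compound 2, which also carries the hydroxy, sits at the high end, but with a different distal aryl. A moderate weakening is expected for the step of a number 16 percentage points higher from compound 3 to compound 4 (beyond the scatter). Compound 4 is expected to give 55%, in the range 32% to 82%.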

Compound 4, a percentage reported as activity, at one concentration (the size of the read-out at that concentration, not a potency): 101%
Compound 4: middle estimate off by 46 percentage points, on the low side, and the stated range ends below it.
By their numbers in this assay, from the lowest: compound 3; then compound 1; then compounds 4 and 2 (each within the scatter of the next).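

In this assay the change from methoxy to hydroxy on the 3-methoxy-5-methylphenyl group now stands as a single step (a number 62 percentage points higher from compound 3 to compound 4 (beyond the scatter)), so with the dimethylamino group in place the effect of compound 3 is lost on removing that methyl. With the hydroxy kept, dimethylamino in place of phenoxy on an aromatic carbon gives no difference beyond the scatter (a number 2 percentage points lower from compound 2 to compound 4 (within the scatter)). Nothing measured here accounts for the large step.

Going by these compounds, whether an ethoxy group or an amine on that aromatic ring behaves like the methoxy or like the hydroxy stays open. Also open, on these data alone, is whether the methoxy step holds with phenoxy in place of dimethylamino.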